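The compounds below may be only part of what the source reports. "The series", "measured", "known", "first", "only" and "open" are said of these compounds alone.

In a functional assay on MDA-MB-231 cells (Homo sapiens) for cytotoxicity, read by MTT assay, with a stated time of 72 h (a lower number here means a stronger inhibitor, a higher number a weaker inhibitor), compound 1 `COc1cc2c(Oc3ccc(NC(=O)N/N=C/c4ccc([N+](=O)[O-])cc4)cc3F)ccnc2cc1OCCCN1CCCC1` gives 970 nM, compound 2 `COc1cc2c(Oc3ccc(NC(=O)N/N=C/c4ccc(C(F)(F)F)cc4)cc3F)ccnc2cc1OCCCN1CCCC1` gives 1800 nM, and compound 3 `COc1ccc(/C=N/NC(=O)Nc2ccc(Oc3ccnc4cc(OCCCN5CCCCC5)c(OC)cc34)c(F)c2)cc1` gives 840 nM.

Compound 3 has the lowest of the three numbers in this assay; its gap to compound 1 lies within the scatter, its gap to compound 2 just beyond it. Compound 4 `COc1cc2c(Oc3ccc(NC(=O)N/N=C/c4ccc(C(F)(F)F)cc4)cc3F)ccnc2cc1OCCCN1CCCCC1` differs from compound 3 by trifluoromethyl in place of methoxy on an aromatic carbon. Among the compounds with values here, no measured step makes this exact exchange. The nearest is a 1.9-fold higher number from compound 1 to compound 2 (0.27 log units; within the scatter), where trifluoromethyl likewise enters. Compound 2 and compound 3 differ in more than one place, so their two values give only a loose comparison. A small rise, at or near the edge of the scatter, is therefore expected for compound 4: a 1.8-fold higher number from compound 3 to compound 4 (0.25 log units; within the scatter). Compound 4 is estimated at 1500 nM, in the range 700 nM to 3200 nM.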

Compound 4, half-maximal inhibitory concentration: 1100 nM
Beside the measured number, compound 4's estimate is 1.4-fold (0.13 log units) above it; measured number inside the range.
By their numbers in this assay, from the lowest: compounds 3, 1, 4 and 2 (each within the scatter of the next, the first and the last beyond it).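

In this assay the change from 4-methoxyphenyl to 4-(trifluoromethyl)phenyl can now be read directly, and a 1.3-fold higher number from compound 3 to compound 4 (0.12 log units; within the scatter) shows that the two groups are not told apart at this position. Within the data shown here, the first reading of the chain end, a 1.6-fold lower number from compound 2 to compound 4 (0.21 log units; within the scatter), likewise does not separate piperidin-1-yl from pyrrolidin-1-yl. No available evidence bears on the reason for either result. From the compounds shown here alone, whether an amine, a carboxylic acid or a nitrile at this position would give a step beyond the scatter remains open. So does the effect of a longer chain carrying the piperidin-1-yl group.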